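Tert-butyl added to the phenyl of compound 1

The compounds below may be only part of what the source reports. "The series", "measured", "known", "first", "only" and "open" are said of these compounds alone.

Two compounds of the shared core carry numbers in a functional assay on XF498 cells (Homo sapiens) for antiproliferative activity, read by MTT assay, with a stated time of 96 h; on this read-out higher numbers stand for weaker inhibition and lower numbers for stronger inhibition. Compound 1 `O=C1C2=C(C(=O)c3ncccc31)C1(CS2)NC(=O)N(c2ccccc2)C1=O` gives 1510 nM, the lower of the two; compound 2 `Cc1ccc(N2NC(=O)NC3(CSC4=C3C(=O)c3ncccc3C4=O)C2=O)cc1` gives 3800 nM, and that gap lies beyond the scatter. Compound 3 `CC(C)(C)c1ccc(N2C(=O)NC3(CSC4=C3C(=O)c3ncccc3C4=O)C2=O)cc1` differs from compound 1 by tert-butyl in place of hydrogen on an aromatic carbon. Going by the values given here, no measured pair shows a step of this kind, so its size and direction rest on no data; a step within the scatter, or a modest one either way, is expected. For compound 3 the estimate is 1800 nM, with a range from 600 nM to 5500 nM. The expected step is a 1.2-fold higher number from compound 1 to compound 3 (0.08 log units; within the scatter), within the scatter.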

Compound 3, half-maximal inhibitory concentration: 850 nM
Estimate against measurement, compound 3: 2.1-fold (0.33 log units) above, and the stated range covers the measured number.
By their numbers in this assay, from the lowest: compounds 3 and 1 (each within the scatter of the next); then compound 2.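

In this assay, tert-butyl on an aromatic carbon of the phenyl of compound 1, para to a large group, gives a 1.8-fold lower number from compound 1 to compound 3 (0.25 log units; within the scatter) and so leaves the number within the scatter. Going by these compounds alone, this position therefore accepts a group of four carbons without a step beyond the scatter, which the earlier compounds could not show. No measurement given here bears on why this step is so small. From the compounds shown here alone, whether an amine, a carboxylic acid or a longer chain at this position would behave the same remains open.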